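Chloro to bromo on the end ring of the series

This account rests on a few compounds, and the source may have more. Where it says the series, first, only, none or still open, it means among the compounds named here.

compound 1 `COc1cc2ncnc(Nc3ccc(NC(=O)c4ccccc4C)cc3)c2cc1OC` 21000 nM
compound 2 `COc1cc2ncnc(Nc3ccc(NC(=O)c4ccc(C)cc4)cc3)c2cc1OC` 19000 nM
compound 3 `COc1cc2ncnc(Nc3ccc(NC(=O)c4ccc(Cl)cc4)cc3)c2cc1OC` 30000 nM

In a functional assay on MCF7 cells (Homo sapiens) for inhibition, read by MTT assay (a higher number here means a weaker inhibitor, a lower number a stronger inhibitor), compound 3 sits level with the other two compounds (a 1.4-fold higher number from compound 1 to compound 3 (0.15 log units; within the scatter) and a 1.6-fold higher number from compound 2 to compound 3 (0.20 log units; within the scatter)). Compound 4 `COc1cc2ncnc(Nc3ccc(NC(=O)c4ccc(Br)cc4)cc3)c2cc1OC` has bromo in place of chloro on an aromatic carbon, para to a large group (bromo in place of chloro on an aromatic carbon). The closest measured swap is chloro in place of methyl on an aromatic carbon (a 1.6-fold higher number from compound 2 to compound 3 (0.20 log units; within the scatter)). The swap of 4-methylphenyl for 2-methylphenyl also stayed small (a 1.1-fold lower number from compound 1 to compound 2 (0.04 log units; within the scatter)). Every measured step stayed within the scatter, so this assay should show no step beyond it for compound 4. The estimate therefore means a 1.1-fold lower number from compound 3 to compound 4 (0.05 log units; within the scatter) as an expected step. Compound 4 is expected at 27000 nM within a range of 14000 nM to 50000 nM in this estimate.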

Compound 4, half-maximal inhibitory concentration: 43000 nM
Beside the measured number, compound 4's estimate is 1.6-fold (0.20 log units) below it; the range from low to high includes it.
By their numbers in this assay, from the lowest: compounds 2, 1, 3 and 4 (each within the scatter of the next, the first and the last beyond it).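

In this assay, bromo in place of chloro at this position gives a 1.4-fold higher number from compound 3 to compound 4 (0.16 log units; within the scatter), so these two halogens cannot be told apart. Even so, this is the first end-ring change to pass the scatter, with a 2.3-fold higher number from compound 2 to compound 4 (0.35 log units; beyond the scatter) and a 2.0-fold higher number from compound 1 to compound 4 (0.31 log units; beyond the scatter), both modest steps towards a weaker inhibitor. Nothing available explains these modest steps. The end rings shown carry only methyl, chloro or bromo, so it stays open whether an amine or a carboxylic acid there would give a clearly stronger inhibitor.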